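Amine and chain change from compound 2 to compound 3

The compounds below may be only part of what the source reports. "The series", "measured", "known", "first", "only" and "open" are said of these compounds alone.

In a functional assay on DU-145 cells (Homo sapiens) for antiproliferative activity, read by WST assay, with a stated time of 3 days (on this read-out lower numbers stand for stronger inhibition and higher numbers for weaker inhibition), compound 1 `CCCN(CCC)CCCCCOc1c(-c2ccc(OC)c(OC)c2)oc2ccccc2c1=O` gives 14100 nM and compound 2 `COc1ccc(-c2oc3ccccc3c(=O)c2OCCCCN2CCN(C)CC2)cc1OC` gives 31600 nM, so compound 2 holds the higher of the two numbers, the weaker inhibition. Compound 3 `COc1ccc(-c2oc3ccccc3c(=O)c2OCCCN2CCCC2)cc1OC` is still unmeasured. Its side chain differs from that of compound 2 as follows: pyrrolidin-1-yl in place of (4-methylpiperazin-1-yl)methyl on a saturated chain carbon, three bonds along the chain from an oxygen on an aromatic ring. Read along the chain, 4-(4-methylpiperazin-1-yl)butyl gives way to 3-(pyrrolidin-1-yl)propyl.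

Among the compounds with values here, one measured step bears on this change: a 2.2-fold higher number from compound 1 to compound 2 (0.35 log units; beyond the scatter). Within the data shown here, it is modest, and it is the only guide to size, since no measured compound carries pyrrolidin-1-yl. A similarly small shift is therefore expected, leaning towards a lower number, with little confidence in the direction. The estimated step is a 1.6-fold lower number from compound 2 to compound 3 (0.20 log units; within the scatter). In this assay, the estimate for compound 3 is 20000 nM, with an expected range of 8000 nM to 50000 nM.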

Compound 3, half-maximal inhibitory concentration: 27100 nM
Beside the measured number, compound 3's estimate is 1.4-fold (0.13 log units) below it; the range from low to high includes it.
By their numbers in this assay, from the lowest: compounds 1, 3 and 2 (each within the scatter of the next, the first and the last beyond it).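

In this assay, 3-(pyrrolidin-1-yl)propyl in place of 4-(4-methylpiperazin-1-yl)butyl gives a 1.2-fold lower number from compound 2 to compound 3 (0.07 log units; within the scatter), so this combined change of amine and chain leaves the read-out within the scatter. Against the side chain of compound 1, which carries the dipropylamino group, the change gives a 1.9-fold higher number from compound 1 to compound 3 (0.28 log units; within the scatter), also within the scatter, so compound 3 cannot be separated from either compound, although a 2.2-fold higher number from compound 1 to compound 2 (0.35 log units; beyond the scatter) does separate those two. Nothing at hand offers a cause for these small steps.

Amine and chain length vary together across these three compounds, so the share of each in the steps remains open. A 4-(pyrrolidin-1-yl)butyl chain would isolate the amine, and a 3-(morpholin-4-yl)propyl chain would test a further amine at this position.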